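The source may hold more compounds than are shown below. What is called first, only, known or untested is meant among the compounds shown, and "the series" means these compounds.

Among the compounds with values here, in a functional assay on HepG2 cells (Homo sapiens) for cytotoxicity, read by MTT assay, with a stated time of 72 h (on this read-out higher numbers stand for weaker inhibition and lower numbers for stronger inhibition), compound 3 `Cc1ccc(S(=O)(=O)OCCCc2cn(-c3cccc(C#N)c3)nn2)cc1` gives 44900 nM, the only exact number so far. Compound 1 `COC(=O)c1ccc(-n2cc(CCCOS(=O)(=O)c3ccc(C)cc3)nn2)cc1` gives > 100000 nM, which is a limit of the assay. Compound 2 `COc1ccc(-n2cc(CCCOS(=O)(=O)c3ccc(C)cc3)nn2)cc1` gives > 100000 nM, which is also a limit. Compound 4 `Cc1ccc(-n2cc(CCCOS(=O)(=O)c3ccc(C)cc3)nn2)cc1` changes one group of compound 3: 4-methylphenyl in place of 3-cyanophenyl on an aromatic nitrogen. Within the data shown here, two measured steps bear on this change. Among the measured compounds shown here, the first is a step that the two limits leave unreadable from compound 1 to compound 2, so it offers no size to build on. The closer guide is an at least 2.2-fold lower number from compound 2 to compound 3 (0.34 log units; beyond the scatter), which came with the arrival of 3-cyanophenyl. Removing that group should therefore bring a modest step to a higher number in this assay, meaning weaker inhibition, and the reading may reach the limit. The expected change is a 2.0-fold higher number from compound 3 to compound 4 (0.30 log units; within the scatter). For compound 4 the estimate is 90000 nM, with an expected range from 40000 nM to 200000 nM.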

Compound 4, half-maximal inhibitory concentration: 100000 nM
Beside the measured number, compound 4's estimate is 1.1-fold (0.05 log units) below it; measured number inside the range.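

In this assay the change to 4-methylphenyl gives a modest step (a 2.2-fold higher number from compound 3 to compound 4 (0.35 log units; beyond the scatter)). Within the data shown here, this is the first step at this position with an exact number at both ends, so 3-cyanophenyl and 4-methylphenyl can be told apart here. Neither a number no higher from compound 2 to compound 4 (the limit leaves the size open) nor a number no higher from compound 1 to compound 4 (the limit leaves the size open) can be read, because the compounds at the start of these steps sit at a limit: the limit of > 100000 nM in this assay, at which 2 of the 4 values shown sit.

The compounds shown leave open whether 4-cyanophenyl would match 3-cyanophenyl. They also leave open whether an aminophenyl or a carboxyphenyl group here would bring the number lower still.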